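The source may hold more compounds than are shown below. What is called first, only, known or untested is meant among the compounds shown, and "the series" means these compounds.

Working notes on the series in a functional assay on HCT-116 cells (Homo sapiens) for inhibition, read by MTT assay, with a stated time of 2 days (on this read-out lower numbers stand for stronger inhibition of growth and higher numbers for weaker inhibition of growth), follow. Here compound 1 (`Nc1ccccc1NC(=O)CCCNCC(=O)Nc1cccc(Cl)c1`) reads 75000 nM on the high side. Compound 2 (`Nc1ccccc1NC(=O)c1ccc(NCC(=O)Nc2ccc([N+](=O)[O-])cc2)cc1`) reads 6500 nM and compound 3 (`Nc1ccccc1NC(=O)c1ccc(NCC(=O)Nc2cccc([N+](=O)[O-])c2)cc1`) reads 9000 nM as a close pair. Compound 3 thus sits with compound 2 and well under the value of compound 1. Compound 4 (`Cc1ccc(NC(=O)CNc2ccc(C(=O)Nc3ccccc3N)cc2)cc1`) carries 4-methylphenyl in place of 3-nitrophenyl on an amide-type nitrogen, with 4-methylphenyl in place of 3-nitrophenyl on an amide-type nitrogen as the counted change. Compound 1 differs from compound 3 in more than this place and offers no direct guide. Going by the values given here, the one measured step at this place swaps 4-nitrophenyl for 3-nitrophenyl, and no measured compound with the shared core of compound 3 carries a 4-methylphenyl. Among the compounds with values here, with a 1.4-fold higher number from compound 2 to compound 3 (0.14 log units; within the scatter) as the only guide, no step beyond the scatter is expected and the direction stays open. The expected change is a 1.1-fold lower number from compound 3 to compound 4 (0.05 log units; within the scatter) as a small estimated step. For compound 4 the estimated value is 8000 nM with an expected range from 3500 nM to 18000 nM in this series.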

Compound 4, concentration for total growth inhibition: > 100000 nM
Compound 4 was reported as a limit (the forecaster's own chance of this, stated with the estimate: 3%); middle value at least 12-fold (1.09 log units) from the limit.
By their numbers in this assay, from the lowest: compounds 2 and 3 (each within the scatter of the next); then compound 1. At a limit, above all of these: compound 4.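

In this assay, compound 4 stands as a limit and not as a number: the limit of > 100000 nM in this assay, at which 1 of the 4 values shown sits.

At this place on the amide-type nitrogen, the earlier pair with 4-nitrophenyl and 3-nitrophenyl stayed within the scatter, so the position looked tolerant of change. The new compound shows otherwise: 4-methylphenyl in place of 3-nitrophenyl gives an at least 11-fold higher number from compound 3 to compound 4 (1.04 log units; beyond the scatter), and methyl in place of nitro on an aromatic carbon gives an at least 15-fold higher number from compound 2 to compound 4 (1.18 log units; beyond the scatter). The group on this nitrogen can therefore shift the read-out strongly, even with the rest of the shared core unchanged.

The compounds shown do not separate the loss of nitro from the gain of methyl. Plain phenyl, 4-aminophenyl or 4-cyanophenyl on the same nitrogen would help to tell these two apart.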